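Swapping Chlorine for a Hydroxyl on an Inactive Core

This account rests on a few compounds, and the source may have more. Where it says the series, first, only, none or still open, it means among the compounds named here.

Compound 3, `Fc1cccc(-c2nc(Nc3ccccc3Cl)c3cc(F)ccc3n2)c1`, belongs to a small set of three close relatives. In a functional assay on MDA-MB-231 cells (Homo sapiens) for cytotoxicity, read by MTT assay, with a stated time of 48 h (a lower number here means a stronger inhibitor, a higher number a weaker inhibitor), compound 3 gives > 50000 nM, which is a limit of the assay rather than a number. Its two neighbours sit at the same limit. Compound 1, `Fc1ccc(Nc2nc(-c3cccc(F)c3)nc3ccc(F)cc23)cc1`, gives > 50000 nM in this assay, also a limit. Compound 2, `Fc1cccc(-c2nc(Nc3ccc(Cl)cc3)c3cc(F)ccc3n2)c1`, gives > 50000 nM in this assay, again a limit. Because all three values sit at the limit of > 50000 nM in this assay, at which 3 of the 3 values shown sit, the steps between them cannot be read: a step that the two limits leave unreadable from compound 1 to compound 2, a step that the two limits leave unreadable from compound 1 to compound 3 and a step that the two limits leave unreadable from compound 2 to compound 3 are all of unknown size.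

Compound 4, `Oc1cccc(Nc2nc(-c3cccc(F)c3)nc3ccc(F)cc23)c1`, differs from compound 3 in one place: 3-hydroxyphenyl in place of 2-chlorophenyl on a nitrogen on an aromatic ring. Going by the values given here, none of the measured steps can be read, so they give no guide to how large this step should be or in which direction. Among the compounds with values here, the only thing the three values show is that three changes to the group on the nitrogen on an aromatic ring left the activity beyond the limit. The expectation for compound 4 is therefore that it stays near that limit, and the step of a number no higher from compound 3 to compound 4 (the limit leaves the size open) is expected to be small. Compound 4 is estimated to give 50000 nM in this assay, with a range from 15000 nM to 150000 nM.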

Compound 4, half-maximal inhibitory concentration: > 50000 nM
Compound 4 ended at the assay's limit (the forecaster's own chance of this, stated with the estimate: 70%); the middle value lies on the limit itself.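

The steps from compound 1, compound 2 and compound 3 to compound 4 cannot be read, because all four compounds share one limit of the measurement: the limit of > 50000 nM in this assay, at which 4 of the 4 values shown sit.

The compounds shown leave open how far apart these four really lie in this assay, and whether any group on the nitrogen would give a readable value on this core.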